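Indolyl-thiazole carboxamides: anilide methoxy removal

A few compounds are considered here, and "the series" means these few. Any claim that something is new, unique, unknown or untested is made for them only; others in the source may bear on it.

Measured compounds:
compound 1, `O=C(NCc1ccccc1)c1csc(-c2c[nH]c3ccccc23)n1`: 41400 nM
compound 2, `COc1ccc(NC(=O)c2csc(-c3cn(Cc4ccc(Cl)cc4)c4ccccc34)n2)cc1`: 90900 nM

Both compounds were tested in a functional assay on HeLa cells (Homo sapiens) for cytotoxicity, read by MTT assay, with a stated time of 48 h, in the presence of a further agent that is not named here; on this read-out lower numbers stand for stronger inhibition and higher numbers for weaker inhibition. Compound 2 stands highest of the two numbers on this read-out; its nearest neighbour is compound 1, whose number is lower by a margin beyond the usual scatter. Among the compounds with values here, the two compounds differ in several places at once, so no single structural step between them can be read from these two values.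

Compound 3, `O=C(Nc1ccccc1)c1csc(-c2cn(Cc3ccc(Cl)cc3)c3ccccc23)n1`, keeps the core of compound 2 and differs from it in one place only: hydrogen in place of methoxy on an aromatic carbon of a six-membered aromatic ring of carbon only, the 4-methoxyphenyl becoming phenyl.

Within the data shown here, no measured pair informs this change. The expected step of a 1.3-fold lower number from compound 2 to compound 3 (0.11 log units; within the scatter) is small, and the estimate for compound 3 in this assay is 70000 nM, with a range from 30000 nM to 160000 nM.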

Compound 3, half-maximal inhibitory concentration: 32100 nM
The estimate for compound 3 lay 2.2-fold (0.34 log units) above the measured number, and the stated range covers the measured number.
By their numbers in this assay, from the lowest: compounds 3 and 1 (each within the scatter of the next); then compound 2.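

In this assay, within the data shown here, the change from 4-methoxyphenyl to phenyl gives a 2.8-fold lower number from compound 2 to compound 3 (0.45 log units; beyond the scatter) and is the first step that can be tied to a single place. Methoxy on this aromatic carbon is therefore not needed for activity in this pair, and its removal moves the number modestly toward stronger inhibition, with compound 3 at 32100 nM on this read-out. No measurement shown accounts for this shift.

As far as these compounds go, whether other groups at this position, such as an amine, a carboxylic acid or a longer alkoxy chain, would move the number in the same direction remains open, as this one pair is all that speaks to the position. Steps involving compound 1 cannot be read, as it differs from the other compounds in several places.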